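The source may hold more compounds than are shown below. What is called first, only, known or untested is meant among the compounds shown, and "the series" means these compounds.

Compound 1 `O=C1C=C(Nc2ccc(C(F)(F)F)cc2)C(=O)c2c1nc1n2[C@H]2OC[C@@H](O)[C@H]2OC1` in a functional assay on HeLa cells (Homo sapiens) for inhibition, read by sulforhodamine B assay (on this read-out lower numbers stand for stronger inhibition and higher numbers for weaker inhibition), gives > 8000 nM, which is a limit of the assay and not a number.
Compound 2 `O=C1C=C(Nc2cccc(Cl)c2)C(=O)c2c1nc1n2[C@H]2OC[C@@H](O)[C@H]2OC1` in this assay gives 6040 nM.
Compound 3 `CCOc1ccc(NC2=CC(=O)c3nc4n(c3C2=O)[C@H]2OC[C@@H](O)[C@H]2OC4)cc1` in this assay gives 3110 nM.

Of the two numbers shown, compound 2 has the highest, and its nearest neighbour is compound 3 with a 1.9-fold lower number from compound 2 to compound 3 (0.29 log units; within the scatter), a gap that stays within the scatter. Compound 1 sits at the limit of > 8000 nM in this assay, at which 1 of the 3 values shown sits, and so contributes no number to compare.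

Compound 4 `O=C1C=C(N2CCCC2)C(=O)c2c1nc1n2[C@H]2OC[C@@H](O)[C@H]2OC1` differs from compound 2 by pyrrolidin-1-yl in place of (3-chlorophenyl)amino on a double-bonded ring carbon. For the measured compounds named here, none of the measured steps bears directly on this exchange: an at least 1.3-fold lower number from compound 1 to compound 2 (0.12 log units; that floor lies within the scatter) and an at least 2.5-fold lower number from compound 1 to compound 3 (0.41 log units; beyond the scatter) both swap one substituted phenyl for another on the amine nitrogen, and the three measured compounds span only a modest range, with one of them at a limit. Going by the values given here, the step to compound 4 removes the aromatic ring and the hydrogen-bond donor altogether, for which no precedent is present among the measured compounds. The expected step is therefore uncertain, estimated as a 1.5-fold higher number from compound 2 to compound 4 (0.17 log units; within the scatter), leaning toward a higher number and with a real chance that only a limit is returned. For compound 4 the estimate in this assay is 9000 nM, with a range from 2500 nM to 30000 nM.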

Compound 4, half-maximal inhibitory concentration: > 16000 nM
Compound 4: no number, only a limit (the forecaster's own chance of this, stated with the estimate: 50%); middle value at least 1.7-fold (0.24 log units) away from the limit.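

Compound 4 gives no number in this assay, only a limit of the assay: the limit of > 16000 nM in this assay, at which 1 of the 4 values shown sits.

Earlier steps only exchanged one substituted phenyl for another on the amine nitrogen, whereas pyrrolidin-1-yl replaces the whole (3-chlorophenyl)amino group on the double-bonded ring carbon, and this gives an at least 2.6-fold higher number from compound 2 to compound 4 (0.42 log units; beyond the scatter). This is the first step shown that removes both the six-membered aromatic ring and the hydrogen-bond donor from this place, and it is a floor on the change, with the true size unknown.

Compound 1, which keeps an aromatic ring and a hydrogen-bond donor at this place, also returns only a limit of the assay, so their presence alone does not secure a number: the limit of > 8000 nM in this assay, at which 1 of the 4 values shown sits.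

The compounds shown leave open whether the aromatic ring, the hydrogen-bond donor or both matter here, as the two leave together in this single change. A cyclopentylamino group would keep the amine hydrogen without the aromatic ring, while a (3-chlorophenyl)(methyl)amino group would keep the ring without that hydrogen, and the two would separate these contributions.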